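The source may hold more compounds than are shown below. What is called first, only, known or untested is meant among the compounds shown, and "the series" means these compounds.

Compound 1 `COc1ccccc1Nc1cc(C)nc(SCc2nc3ccccc3[nH]2)n1` is one of two measured members of a small series built on a shared core. Among the compounds with values here, in a functional assay on ECa-109 cells (Homo sapiens) for cytotoxicity, read by MTT assay, with a stated time of 72 h (a higher number here means a weaker inhibitor, a lower number a stronger inhibitor), compound 1 gives 34400 nM, which is the only actual number recorded. Compound 2 `Cc1cc(Nc2cccc(C(F)(F)F)c2)nc(SCc2nc3ccccc3[nH]2)n1` is the other measured member. In this assay compound 2 gives > 100000 nM, and this is a limit of the assay rather than a measured number (the limit of > 100000 nM in this assay, at which 1 of the 2 values shown sits). Within the data shown here, compound 1 therefore stands as the only compound with a defined value, and it is already a weak inhibitor.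

Compound 3 `Cc1cc(N(C)Cc2ccccc2)nc(SCc2nc3ccccc3[nH]2)n1` has not yet been tested. Compared with compound 1 it carries benzyl(methyl)amino in place of (2-methoxyphenyl)amino on an aromatic carbon. Among the measured compounds shown here, no step between two measured compounds shows what this kind of change does here, so the expectation rests on compound 1 alone. Because compound 1 is already weak at 34400 nM, the expected step of a 1.5-fold higher number from compound 1 to compound 3 (0.16 log units; within the scatter) is modest, leaning toward weaker inhibition, and may not exceed the usual scatter. Compound 3 is therefore expected to give about 50000 nM, within a range from 15000 nM to 150000 nM.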

Compound 3, half-maximal inhibitory concentration: > 100000 nM
Compound 3 ended at the assay's limit (the forecaster's own chance of this, stated with the estimate: 40%); middle value at least 2.0-fold (0.30 log units) away from the limit.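

In this assay, within the data shown here, putting benzyl(methyl)amino in place of (2-methoxyphenyl)amino on this aromatic carbon gives an at least 2.9-fold higher number from compound 1 to compound 3 (0.46 log units; beyond the scatter), the first step that can be read at all. Compound 3 gives > 100000 nM, which is a limit of the assay and not a number. The position is therefore not indifferent to the group it carries, since this swap keeps a six-membered aromatic ring of carbon only in the group, yet the modest effect of compound 1 does not survive it, and compound 1 stays the only one of the three with a defined number: the limit of > 100000 nM in this assay, at which 2 of the 3 values shown sit.

On these data alone, the true size of the step stays open, as a limit gives only its lower bound, and this single swap changes several things at once, including the loss of the methoxy oxygen and of the hydrogen-bond donor, so the result cannot be assigned to any one of them. A plain benzylamino group, which would keep the nitrogen's hydrogen, or a 2-ethoxyphenylamino group, which would stay close to compound 1, could help separate these changes.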